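The source may hold more compounds than are shown below. What is called first, only, known or untested is meant among the compounds shown, and "the series" means these compounds.

Of the compounds shown here, two of this set have been measured in an ADME assay on BaF3 cells (Mus musculus) for antiproliferative activity, read by CellTiter-Glo and CCK-8 assay, with a stated time of 72 h; on this read-out higher numbers stand for weaker inhibition of growth and lower numbers for stronger inhibition of growth. Within the data shown here, compound 1, `Cc1ccc(Nc2ncc3c(n2)N(C)C(=O)N(c2cc(NC(=O)c4cccc(C(F)(F)F)c4)ccc2C)C3)cc1N`, is the one that gives a number: in this assay compound 1 gives 440 nM. Compound 2, `CNc1nc(Nc2ccc(C)c([N+](=O)[O-])c2)ncc1C(=O)Nc1cc(NC(=O)c2ccccc2OC)ccc1C`, differs from it in the core and in the outer amide. For compound 2 this assay reports only a limit, > 10000 nM, so where compound 2 stands is known only as the limit of > 10000 nM in this assay, at which 1 of the 2 values shown sits. Among the measured compounds shown here, no step between measured compounds is counted here, since compound 1 and compound 2 differ in several places at once.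

Compound 3, `CNc1nc(Nc2ccc(C)c([N+](=O)[O-])c2)ncc1C(=O)Nc1cc(NC(=O)c2cc(OC)cc(OC)c2)ccc1C`, keeps the whole of compound 2 apart from one change: 3,5-dimethoxyphenyl in place of 2-methoxyphenyl on a carbonyl carbon. With compound 2 sitting at a limit, the change can only be judged against that limit. For the measured compounds named here, no step within this set tells what such a change does in this assay, so no shift beyond the usual scatter is expected, and the expected step is a step that the limit leaves unreadable from compound 2 to compound 3. Compound 3 is therefore expected to give about 15000 nM in this assay, in a range from 3000 nM to 60000 nM, most likely again as a limit rather than a number.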

Compound 3, concentration for 50% growth inhibition: > 10000 nM
Compound 3 was reported as a limit (the forecaster's own chance of this, stated with the estimate: 80%); the middle value lies beyond the limit too.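

No step from compound 2 to compound 3 can be read, because both compounds are reported only as the same kind of limit: the limit of > 10000 nM in this assay, at which 2 of the 3 values shown sit.

The compounds shown leave open whether 3,5-dimethoxyphenyl in place of 2-methoxyphenyl on a carbonyl carbon changes growth inhibition at all in this assay.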